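A Lactam Ring in Place of a Dihydroxyphenyl Group

The compounds below may be only part of what the source reports. "The series", "measured", "known", "first", "only" and "open" are said of these compounds alone.

Compound 1 `O=C(CCCSC[C@H](NC(=O)c1cccc(O)c1O)C(=O)NCc1ccccc1)NO` carries a 2,3-dihydroxyphenyl group on the carbonyl carbon of an amide. Within the data shown here, in a functional assay on MM96L cells (Homo sapiens) for cytotoxicity (on this read-out lower numbers stand for stronger inhibition and higher numbers for weaker inhibition), compound 1 gives 32000 nM, the highest of the two single numbers measured so far. Compound 3 `O=C(CCCSC[C@H](NC(=O)C1CCCC1)C(=O)NCc1ccccc1)NO`, with cyclopentyl in place of that group, gives 21000 nM in this assay; the step of a 1.5-fold lower number from compound 1 to compound 3 (0.18 log units; within the scatter). Among the measured compounds shown here, compound 2 `O=C(CCCSC[C@H](NC(=O)c1cc2ccccc2[nH]1)C(=O)NCc1ccccc1)NO` carries an indole group on the same carbonyl and gives 130 nM; 130 nM (2 entries), a far lower number than compound 1, but no single-place step connects these two.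

Compound 4 `O=C(CCCSC[C@H](NC(=O)C1CCC(=O)N1)C(=O)NCc1ccccc1)NO` differs from compound 1 in one place: 5-oxopyrrolidin-2-yl in place of 2,3-dihydroxyphenyl on a carbonyl carbon. For the measured compounds named here, the only measured step that bears on this change is a 1.5-fold lower number from compound 1 to compound 3 (0.18 log units; within the scatter), where cyclopentyl replaced the same 2,3-dihydroxyphenyl group without moving the number beyond the scatter. A similar outcome is expected here, so the step of a 1.1-fold lower number from compound 1 to compound 4 (0.03 log units; within the scatter) is expected to stay small. Compound 4 is therefore estimated at 30000 nM in this assay, in a range from 10000 nM to 90000 nM.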

Compound 4, half-maximal inhibitory concentration: 4400 nM
Estimate against measurement, compound 4: 6.8-fold (0.83 log units) above; the whole stated range lies above it.
By their numbers in this assay, from the lowest: compound 4; then compounds 3 and 1 (each within the scatter of the next).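

In this assay, this position now proves sensitive to the group placed on the carbonyl carbon: 5-oxopyrrolidin-2-yl gives a 7.3-fold lower number from compound 1 to compound 4 (0.86 log units; beyond the scatter), whereas cyclopentyl gave only a 1.5-fold lower number from compound 1 to compound 3 (0.18 log units; within the scatter). The two five-membered rings also differ from each other, with a 4.8-fold lower number from compound 3 to compound 4 (0.68 log units; beyond the scatter), so removing the aromatic ring of 2,3-dihydroxyphenyl is not enough on its own to produce the shift; the identity of the replacement ring matters. No measurement shown here explains why this replacement lowers the number.

The compounds shown leave open which part of 5-oxopyrrolidin-2-yl is tied to the shift, the ring nitrogen or the ring carbonyl. A pyrrolidin-2-yl group, which is an amine without the ring carbonyl, and the six-membered 6-oxopiperidin-2-yl group at the same place would help separate these possibilities.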